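This account rests on a few compounds, and the source may have more. Where it says the series, first, only, none or still open, it means among the compounds named here.

Measured so far:
Compound 1, `O=C(O)c1ccc2nc(N3CCC(OCc4c(-c5c(Cl)cccc5Cl)noc4C4CC4)CC3)sc2c1`, gives 0.81 in an ADME assay on microsomes from liver (Homo sapiens); a higher number here means that the liver removes a larger share of the compound in one pass, a lower number that the liver removes a smaller share.
Compound 2, `O=C(O)c1ccc2nc(N3CCC(OCc4c(-c5c(F)cccc5F)noc4C4CC4)CC3)sc2c1`, gives 0.27 in this assay.

Compound 2 holds the lower of the two numbers; its nearest neighbour is compound 1, and the step a number 0.54 lower from compound 1 to compound 2 (beyond the scatter) separates them. Compound 3, `O=C(O)c1ccc2nc(N3CCC(OCc4c(-c5ccccc5C(F)(F)F)noc4C4CC4)CC3)sc2c1`, is not yet measured. It differs from compound 2 in one place: 2-(trifluoromethyl)phenyl in place of 2,6-difluorophenyl on an aromatic carbon.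

Going by the values given here, only one measured step bears on this change, the large step a number 0.54 lower from compound 1 to compound 2 (beyond the scatter), and it concerns a different exchange at the same aromatic carbon. It shows that the group at this carbon can move this assay strongly, but it does not tell the direction for a 2-(trifluoromethyl)phenyl group. Compound 3 is expected to sit between the two measured compounds, with an estimated step a number 0.28 higher from compound 2 to compound 3 (beyond the scatter) upward from compound 2, probably beyond the scatter but with wide uncertainty. The estimate for compound 3 is 0.55, with a range from 0.3 to 0.8.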

Compound 3, hepatic extraction ratio: 0.38
Estimate against measurement, compound 3: 0.17 above; low and high end bracket the measured number.
By their numbers in this assay, from the lowest: compound 2; then compound 3; then compound 1.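

Set against 2,6-difluorophenyl, the 2-(trifluoromethyl)phenyl group gives a number 0.11 higher from compound 2 to compound 3 (beyond the scatter) in this assay, while set against 2,6-dichlorophenyl it gives a number 0.43 lower from compound 1 to compound 3 (beyond the scatter) and so stays much closer to the fluorinated partner. Among these three compounds, the two groups that carry fluorine both sit well below compound 1, so a group with more heavy atoms than 2,6-difluorophenyl can still keep the number low at this carbon. Nothing available explains why these groups differ in this way.

What the compounds shown leave open is where a plain phenyl, a 2-chlorophenyl or a 2,6-dimethylphenyl group at this carbon would fall in this assay. They also leave open whether the same order would hold if a longer chain took the place of the cyclopropyl group.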